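Adding Chloro to the Weakest Member of a Hydrazone Series

The source may report more compounds than this note shows. Statements on the series, on what has been measured and on what is new or still open speak of the compounds shown alone.

Measured so far:
- Compound 1, `O=C(N/N=C/c1c(-c2cc3ccc(Br)cc3oc2=O)[nH]c2ccccc12)c1ccccc1`: 9100 nM
- Compound 2, `O=C(N/N=C/c1c(-c2cc3ccc(Br)cc3oc2=O)[nH]c2ccccc12)c1ccc(Cl)cc1`: 13800 nM
- Compound 3, `O=C(N/N=C/c1c(-c2cc3ccc(Br)cc3oc2=O)[nH]c2ccccc12)c1ccccc1F`: > 200000 nM

All three share one core and differ only in the aromatic ring attached to the carbonyl. In a functional assay on MCF7 cells (Homo sapiens) for inhibition, read by MTT assay, with a stated time of 48 h (on this read-out lower numbers stand for stronger inhibition and higher numbers for weaker inhibition), compound 1 gives 9100 nM. Compound 2 carries a chloro on that ring, and the step of a 1.5-fold higher number from compound 1 to compound 2 (0.18 log units; within the scatter) stays within the scatter, so the two cannot be told apart. Compound 3 instead carries a fluoro, and its value is a limit of the assay, not a number (the limit of > 200000 nM in this assay, at which 1 of the 3 values shown sits); compound 3 therefore stands at the weak end of what this assay can show.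

Compound 4, `O=C(N/N=C/c1c(-c2cc3ccc(Br)cc3oc2=O)[nH]c2ccccc12)c1ccc(Cl)cc1F`, has not been measured. It differs from compound 3 by chloro in place of hydrogen on an aromatic carbon. Among the compounds with values here, the closest measured step is the one from compound 1 to compound 2, where the same kind of chloro addition changed nothing beyond the scatter. On that basis the chloro is not expected to move compound 4 away from where compound 3 sits, and the step of a number no higher from compound 3 to compound 4 (the limit leaves the size open) in this assay is expected to lie within the scatter. Compound 4 is therefore estimated at 200000 nM, in the range 80000 nM to 500000 nM, most likely again reported only as a limit.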

Compound 4, half-maximal inhibitory concentration: > 200000 nM
Compound 4: a limit, no number; the forecaster's own chance of this, stated with the estimate: 70%; the middle value sits exactly at the limit.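

What is new is that the fluoro change now has a second case: on the ring that already carries the chloro, it gives an at least 14-fold higher number from compound 2 to compound 4 (1.16 log units; beyond the scatter), and the two cases can be set side by side in this assay: the same change on two cores in this assay, an at least 21-fold higher number (1.34 log units; beyond the scatter) from compound 1 to compound 3 and an at least 14-fold higher number (1.16 log units; beyond the scatter) from compound 2 to compound 4; the limit leaves it open whether they differ

With 4-chloro-2-fluorophenyl in place of phenyl, the result is an at least 21-fold higher number from compound 1 to compound 4 (1.34 log units; beyond the scatter), so adding the chloro to the fluoro-bearing ring does not bring back a readable value. Compound 3 and compound 4 both stand at a limit of the assay, not at a number, so the step between them cannot be read: the limit of > 200000 nM in this assay, at which 2 of the 4 values shown sit.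

The compounds shown leave open how far each of these two compounds lies past that limit, and so whether the chloro has any effect at all on the fluoro-bearing ring. They also leave open whether the large step belongs to fluoro in particular or would also appear with a different group at that place on the ring, such as a methoxy group or an amine.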